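Dichlorophenyl in Place of Methoxyphenyl on a Shared Core

The source may hold more compounds than are shown below. What is called first, only, known or untested is meant among the compounds shown, and "the series" means these compounds.

Compound 1 `COc1ccc(-c2cccc(COc3ccc([C@H](CC(=O)O)c4nccn4C)cc3)c2)cc1` gives "not determined" (no result reported) in an assay on CHO cells for agonist activity at Free fatty acid receptor 1 (Homo sapiens), read by luminescence, with a stated time of 20 s, in the presence of a further agent that is not named here (on this read-out higher numbers stand for an effect only at larger amounts of compound and lower numbers for an effect already at smaller amounts), so it stands on no single number. Its close relative compound 2 `Cc1cc(F)ccc1-c1cccc(COc2ccc([C@H](CC(=O)O)c3nccn3C)cc2)c1` gives 21000 nM in this assay. Compound 3 `Cn1ccnc1[C@@H](CC(=O)O)c1ccc(OCc2cccc(-c3ccc(Cl)cc3Cl)c2)cc1` differs from compound 1 by 2,4-dichlorophenyl in place of 4-methoxyphenyl on an aromatic carbon. Going by the values given here, with no measured step to lean on, any change in this assay on going from compound 1 to compound 3 is expected to be modest, within or only slightly beyond the scatter, in either direction. Because compound 2 gives 21000 nM as the nearest measured anchor, compound 3 is expected to show about 10000 nM in this assay, with a likely range from 2000 nM to 50000 nM.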

Compound 3, half-maximal effective concentration: 30000 nM
For compound 3 the middle estimate is 3.0-fold (0.48 log units) below the measured one; measured number inside the range.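

In this assay the step is a 1.4-fold higher number from compound 2 to compound 3 (0.15 log units; within the scatter) and so, at this position on the shared core, 2,4-dichlorophenyl and 4-fluoro-2-methylphenyl are not told apart. Compound 1 has no single number, so the step from 4-methoxyphenyl to 2,4-dichlorophenyl cannot be read. Nothing measured here offers an explanation for this result. The compounds shown leave open whether an amine or a carboxylic acid in place of the 2,4-dichlorophenyl would move the number beyond the scatter.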